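Losing the methoxy group from compound 2

This account rests on a few compounds, and the source may have more. Where it says the series, first, only, none or still open, it means among the compounds named here.

In a functional assay on RS4-11 cells (Homo sapiens) for inhibition, read by CCK-8 assay, with a stated time of 48 h, tested at 20 uM (on this read-out lower numbers stand for less inhibition of growth and higher numbers for more inhibition of growth at the one concentration tested), compound 1 (`COc1ccc(Cc2nnc(NC(=O)/C(C#N)=C/c3ccccc3OS(=O)(=O)c3ccc([N+](=O)[O-])cc3)s2)cc1`) gives 70%. Compound 2 (`COc1ccc(Cc2nnc(NC(=O)/C(C#N)=C/c3ccccc3OS(=O)(=O)c3ccc(Cl)cc3)s2)cc1`) gives 79%, which places it level with compound 1 within the scatter. Compound 3 (`N#C/C(=C\c1ccccc1OS(=O)(=O)c1ccc(Cl)cc1)C(=O)Nc1nnc(Cc2ccccc2)s1`) has hydrogen in place of methoxy on an aromatic carbon. Going by the values given here, the only measured step, a number 9 percentage points higher from compound 1 to compound 2 (within the scatter), lies elsewhere in the structure, so it bears only loosely on this change, and no step at this place has been measured. No shift beyond the scatter is therefore expected, and the estimated step is a number 6 percentage points lower from compound 2 to compound 3 (within the scatter). Compound 3 is expected at 73%, within an estimated range of 52% to 90%.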

Compound 3, percent growth inhibition at one concentration: 73%
Beside the measured number, compound 3's estimate shows no gap at the digits printed, within the range that was stated.
By their numbers in this assay, from the lowest: compounds 1, 3 and 2 (each within the scatter of the next).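

In this assay, going by these compounds alone, the change from 4-methoxybenzyl to benzyl gives the first reading at this position (a number 6 percentage points lower from compound 2 to compound 3 (within the scatter)). Growth inhibition at the one concentration tested therefore does not depend on the methoxy group in this pair. Nothing available accounts for this step. Still open, from the compounds shown here alone, is whether a hydroxyl, a fluoro group or an amine at this place on the aromatic carbon would stay within the same range. Going by these compounds, it is also open whether losing the methoxy group would read the same with the nitro group of compound 1 in place of chloro.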